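The source may report more compounds than this note shows. Statements on the series, on what has been measured and on what is new or still open speak of the compounds shown alone.

Measured so far:
compound 1, `CC[C@H](C)[C@H](N)CN(C(=O)[C@@H]1C[C@H]1c1ccc(C#N)cc1)c1ccc(-c2ccccc2)cc1`: > 25000 nM
compound 2, `CC(C)C[C@H](N)CN(C(=O)[C@@H]1C[C@H]1c1ccccc1)c1ccc(-c2cccnc2)cc1`: 10000 nM

Going by the values given here, in a functional assay for agonist activity at G protein-coupled receptor 88 (Homo sapiens), read by HTRF and cAMP accumulation (a higher number here means that more compound is needed for the effect, a lower number that less compound is needed), compound 2 gives 10000 nM, the only number reported. For compound 1 the value > 25000 nM is a limit of the assay and not a number; this is the point marked by the limit of > 25000 nM in this assay, at which 1 of the 2 values shown sits. Compound 2 thus stands as the sole measured point with a numerical read-out.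

Compound 3, `COc1ccccc1-c1ccc(N(C[C@@H](N)CC(C)C)C(=O)[C@@H]2C[C@H]2c2ccccc2)cc1`, has not been measured. It differs from compound 2 in one place: 2-methoxyphenyl in place of pyridin-3-yl on an aromatic carbon. Among the compounds with values here, no measured pair shows this change, so its size cannot be read from data. Without such a measured step, the expectation in this assay is for a step that stays within scatter or drifts modestly towards less compound needed, estimated as a 2.0-fold lower number from compound 2 to compound 3 (0.30 log units; within the scatter). Compound 3 is therefore expected at 5000 nM, with a range from 1000 nM to 25000 nM.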

Compound 3, half-maximal effective concentration: 3200 nM
Estimate against measurement, compound 3: 1.6-fold (0.19 log units) above, and the stated range covers the measured number.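

In this assay, 2-methoxyphenyl in place of pyridin-3-yl, on an aromatic carbon para to a large group, gives a 3.1-fold lower number from compound 2 to compound 3 (0.49 log units; beyond the scatter). Going by these compounds alone, this is the first readable step, and it shows that the number responds to the group at this position and that a ring of carbon only, carrying a methoxy group, is compatible with a lower number. The change swaps the ring and adds the methoxy group in one move, so this single step cannot separate the two.

Within the data shown here, compound 1 differs from compound 2 in more than one place and adds no step, its value being a limit of the assay and not a number: the limit of > 25000 nM in this assay, at which 1 of the 3 values shown sits. Still open, going by these compounds, are the contribution of the methoxy group alone and what a 2-ethoxyphenyl or 2-aminophenyl would give at this place.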